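Removing the methyl from compound 3: what to expect

The source may hold more compounds than are shown below. What is called first, only, known or untested is meant among the compounds shown, and "the series" means these compounds.

Compound 1, `COc1cccc(NS(=O)(=O)c2ccc(N3CCNC3=O)cc2)c1`: 120 nM
Compound 2, `Cc1cc(C)cc(NS(=O)(=O)c2ccc(N3CCNC3=O)cc2)c1`: 82 nM
Compound 3, `Cc1cccc(NS(=O)(=O)c2ccc(N3CCNC3=O)cc2)c1`: 110 nM

In a functional assay on HT-29 cells (Homo sapiens) for antiproliferative activity, read by sulforhodamine B assay, with a stated time of 48 h (a higher number here means a weaker inhibitor, a lower number a stronger inhibitor), compound 3 sits in the middle of the three measured numbers, and the steps of a 1.1-fold lower number from compound 1 to compound 3 (0.04 log units; within the scatter) and a 1.3-fold higher number from compound 2 to compound 3 (0.13 log units; within the scatter) are both small, so the three compounds are hard to tell apart. Compound 4, `O=C1NCCN1c1ccc(S(=O)(=O)Nc2ccccc2)cc1`, differs from compound 3 by hydrogen in place of methyl on an aromatic carbon. The step that bears on this is a 1.3-fold higher number from compound 2 to compound 3 (0.13 log units; within the scatter), the same kind of change on the same ring, and it stayed within the scatter, as did a 1.5-fold lower number from compound 1 to compound 2 (0.17 log units; within the scatter). A step of similar size, or none beyond the scatter, is therefore expected in this assay. For compound 4 the estimated value is 140 nM, with a range of 70 nM to 280 nM, meaning an expected step of a 1.3-fold higher number from compound 3 to compound 4 (0.10 log units; within the scatter).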

Compound 4, half-maximal inhibitory concentration: 280 nM
For compound 4 the middle estimate is 2.0-fold (0.30 log units) below the measured one, within the range that was stated.
By their numbers in this assay, from the lowest: compounds 2, 3 and 1 (each within the scatter of the next); then compound 4.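

In this assay, among these compounds, the unsubstituted phenyl is the first change on this ring to go beyond the scatter, with a 2.5-fold higher number from compound 3 to compound 4 (0.41 log units; beyond the scatter) on losing the methyl, a 3.4-fold higher number from compound 2 to compound 4 (0.53 log units; beyond the scatter) on losing both methyls of 3,5-dimethylphenyl, and a 2.3-fold higher number from compound 1 to compound 4 (0.37 log units; beyond the scatter) on losing the methoxy. So among these compounds, having either methyl or methoxy on this ring gives a lower number than having hydrogen alone. Nothing measured here explains why. Still open, on these data alone, is whether an amine or a carboxylic acid at the same place would also give a lower number than hydrogen.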